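The source may report more compounds than this note shows. Statements on the series, on what has been measured and on what is new or still open speak of the compounds shown alone.

In a functional assay on HT-29 cells (Homo sapiens) for inhibition, in the presence of a further agent that is not named here (on this read-out lower numbers stand for stronger inhibition of growth and higher numbers for weaker inhibition of growth), compound 3 `Nc1ncc(-c2ccc(NCc3ccc(Cl)cc3)c([N+](=O)[O-])c2)cn1` gives 25000 nM. Compound 1 `CCc1nc(N)nc(N)c1-c1ccc(NCc2ccccc2OC)c([N+](=O)[O-])c1` gives 11600 nM, a lower number than that of compound 3, and the gap between the two lies beyond the scatter. Going by the values given here, of the two exact numbers available, the one for compound 3 is therefore the higher, which means weaker inhibition of growth.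

Compound 2 `CCc1nc(N)nc(N)c1-c1ccc2[nH]c(-c3ccc(Cl)cc3)[n+]([O-])c2c1` is reported only as > 50000 nM, and this is a limit of the assay, not a number.

Compound 4 `Nc1ncc(-c2ccc(NCc3ccc(F)cc3)c([N+](=O)[O-])c2)cn1` has not yet been measured. It differs from compound 3 in one place: fluoro in place of chloro on an aromatic carbon. This puts fluoro in place of chloro on an aromatic carbon, para to a large group, so that 4-chlorobenzyl becomes 4-fluorobenzyl.

Among the compounds with values here, no pair of measured compounds differs in only one place, so the size of this change has no direct precedent in the data. Starting from compound 3 at 25000 nM, no shift beyond the scatter is expected in this assay, with at most a slight lean towards a higher number. The estimated step of a 1.1-fold higher number from compound 3 to compound 4 (0.05 log units; within the scatter) is accordingly small. In this assay the estimate for compound 4 is 28000 nM, with an expected range of 12000 nM to 60000 nM.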

Compound 4, concentration for 50% growth inhibition: 38000 nM
Compound 4: the middle estimate sits 1.4-fold (0.13 log units) below what was measured; measured number inside the range.
By their numbers in this assay, from the lowest: compound 1; then compounds 3 and 4 (each within the scatter of the next). At a limit, above all of these: compound 2.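

Going by these compounds alone, the exchange of 4-chlorobenzyl for 4-fluorobenzyl gives the first step in this assay between two compounds that differ in one place (a 1.5-fold higher number from compound 3 to compound 4 (0.18 log units; within the scatter)). On this aromatic carbon, para to a large group, the two halogens are therefore not told apart by this read-out, and inhibition of growth stays as weak with fluoro as with chloro. The top of the measurable range is also not far off, and compound 2 stands there at a limit, which is not a number: the limit of > 50000 nM in this assay, at which 1 of the 4 values shown sits.

Within the data shown here, what the compounds leave open is whether any other group at this place, such as an amine, a carboxylic acid or a trifluoromethyl group, would move the number beyond the scatter, since chloro and fluoro are the only two groups compared here. As far as these compounds go, it also remains open whether the same exchange would give a similarly small step on another core, such as the 4-chlorophenyl group of compound 2, as this single pair speaks only for the core of compound 3.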